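This account rests on a few compounds, and the source may have more. Where it says the series, first, only, none or still open, it means among the compounds named here.

Measured in an ADME assay on CCD-1095SK cells (Homo sapiens) for antiproliferative activity, read by crystal violet staining, with a stated time of 96 h (a lower number here means that less compound is needed, a higher number that more compound is needed for the effect), so far:
compound 1 `O[C@@H]1[C@@H](O)[C@H](Oc2ccc3ccccc3c2)OC[C@H]1O` gives 243 uM; 50 uM (2 entries)
compound 2 `O[C@@H]1[C@@H](F)[C@H](Oc2ccc3ccccc3c2)OC[C@H]1O` gives 12 uM
compound 3 `O[C@H]1[C@H](Oc2ccc3ccccc3c2)OCC[C@@H]1O` gives 285 uM

Of the two compounds with a single number in this assay, compound 2 has the lower one; compound 3 stands well beyond the scatter above it. Compound 1 carries two entries, (the several entries of compound 1 in this assay, 243 uM; 50 uM (2 entries)), which do not settle on one number and are read as a spread rather than a point. Among the measured compounds shown here, no two measured compounds differ in only one place, so there is no measured step to lean on.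

Compound 4 `CO[C@H]1[C@H](Oc2ccc3ccccc3c2)OC[C@@H](O)[C@@H]1O` differs from compound 2 by methoxy in place of fluoro on a saturated ring carbon. For the measured compounds named here, no measured pair shows this exchange, so the direction is taken from the numbers alone: compound 1 and compound 3 both lie above compound 2 in this assay, and the methoxy is expected to move the number back up rather than further down. The step from compound 2 to compound 4 is therefore expected to be a 5.0-fold higher number from compound 2 to compound 4 (0.70 log units; beyond the scatter), a loss beyond the scatter. Compound 4 is estimated at 60 uM in this assay, with a range from 15 uM to 250 uM.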

Compound 4, concentration for half-maximal effect: 55 uM
Compound 4: the middle estimate sits 1.1-fold (0.04 log units) above what was measured; measured number inside the range.
By their numbers in this assay, from the lowest: compound 2; then compound 4; then compound 3.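

In this assay, methoxy in place of fluoro on a saturated ring carbon gives a 4.6-fold higher number from compound 2 to compound 4 (0.66 log units; beyond the scatter), the only measured step in the series shown. This position is therefore not indifferent to its group: a single exchange there moves the number beyond the scatter, and less compound is needed with fluoro than with methoxy. Compound 1, which carries a hydroxy group at the same place, cannot be ranked against either compound, as its entries give a spread rather than a single number: the several entries of compound 1 in this assay, 243 uM; 50 uM (2 entries)

From the compounds shown here alone, one exchange sets no trend, so it remains open whether the oxygen or the added carbon of the methoxy accounts for the step. Going by these compounds, how an amine or an ethoxy group at this carbon would compare with fluoro and methoxy also remains open.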